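Extending a terminal hydroxy chain into a sulfonic acid

The source may report more compounds than this note shows. Statements on the series, on what has been measured and on what is new or still open speak of the compounds shown alone.

Two compounds have been run in a functional assay on HEK293 cells for agonist activity at 5-hydroxytryptamine receptor 4 (Homo sapiens), read by cAMP accumulation; on this read-out lower numbers stand for an effect already at smaller amounts and higher numbers for an effect only at larger amounts of compound. Compound 1 `CC(C)n1c(=O)n(C(=O)NCCN2CCNCC2)c2ccccc21` gives 7.94 nM in this assay. Compound 2 `COc1cc(N)c(Cl)cc1C(=O)NC1CCN(CCCCCO)CC1` gives 15.9 nM in this assay, the higher of the two numbers, though its gap to compound 1 lies within the scatter, so the two cannot be ranked against each other. Among the measured compounds shown here, no pair of measured compounds differs in a single place, so no step size is established from the data themselves.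

Compound 3 `COc1cc(N)c(Cl)cc1C(=O)NC1CCN(CCCCCCCCS(=O)(=O)O)CC1` is not yet measured. It differs from compound 2 by 3-sulfopropyl in place of hydroxy on a saturated chain carbon, five bonds along the chain from an amine nitrogen in a ring. For the measured compounds named here, with no single-point step available to guide the size, the expected step in this assay from compound 2 to compound 3 is modest, a 1.6-fold higher number from compound 2 to compound 3 (0.20 log units; within the scatter), and could in either direction fall within the scatter. Compound 3 is therefore estimated at 25 nM, with a range from 6 nM to 100 nM.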

Compound 3, half-maximal effective concentration: 1000 nM
For compound 3 the middle estimate is 40-fold (1.60 log units) below the measured one; measured number above the stated range.
By their numbers in this assay, from the lowest: compounds 1 and 2 (each within the scatter of the next); then compound 3.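

In this assay, the saturated chain carbon five bonds along the chain from an amine nitrogen in a ring proves sensitive to what it carries: 3-sulfopropyl in place of hydroxy gives a 63-fold higher number from compound 2 to compound 3 (1.80 log units; beyond the scatter). This is the first step that can be read among these compounds, and it shows that a change at this end of the chain can move the number well beyond the scatter, towards an effect only at larger amounts of compound. No measurement at hand bears on why the step is this large.

The change lengthens the chain and replaces its end group in a single move, so the compounds shown do not tell which of the two carries the step. A longer chain ending in hydroxy, or a chain of the same length ending in a carboxylic acid or an amine, would separate the two.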